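This account rests on a few compounds, and the source may have more. Where it says the series, first, only, none or still open, it means among the compounds named here.

Compound 1 `O=C(Nc1cccc(-n2cc(-c3ccncc3)c(-c3cc(O)cc(Cl)c3)n2)c1)Nc1ccc(Cl)c(C(F)(F)F)c1` and compound 2 `COc1cc(Cl)cc(-c2nn(-c3cccc(NC(=O)Nc4ccc(Cl)c(C(F)(F)F)c4)c3)cc2-c2ccncc2)c1` share one core and differ in a single place. In a functional assay on RXF 393 cells (Homo sapiens) for inhibition, read by sulforhodamine B assay, with a stated time of 48 h, tested at 10 uM (a lower number here means a stronger effect, a higher number a weaker effect of the compound at the concentration tested), compound 1 gives -49.5%, and compound 2 gives -30%. Among the measured compounds shown here, the one step seen so far is a number 19.5 percentage points higher from compound 1 to compound 2 (beyond the scatter). Compound 2 therefore stands at the higher, that is weaker, end of the two numbers, above compound 1 by a margin beyond the scatter.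

Compound 3 `COc1cc(Cl)cc(-c2nn(-c3cccc(NC(=O)c4cccc(C(F)(F)F)c4)c3)cc2-c2ccncc2)c1` is the next step. It differs from compound 2 by 3-(trifluoromethyl)phenyl in place of (4-chloro-3-(trifluoromethyl)phenyl)amino on a carbonyl carbon. For the measured compounds named here, no measured step touches this part of the molecule: the only known step changed the oxygen substituent, not the group on the carbonyl carbon, so it gives no direct guide. With nothing to anchor the direction, the expected step of a number 15 percentage points higher from compound 2 to compound 3 (beyond the scatter) is small and uncertain, with a wide range allowed. For compound 3 the estimate is -15%, expected between -45% and 15%.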

Compound 3, a percentage reported as activity, at one concentration (the size of the read-out at that concentration, not a potency): 40.5%
Estimate against measurement, compound 3: 55.5 percentage points below, and the stated range ends below it.
By their numbers in this assay, from the lowest: compound 1; then compound 2; then compound 3.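

The group on the carbonyl carbon matters much more in this assay than the oxygen substituent: replacing it gives a number 70.5 percentage points higher from compound 2 to compound 3 (beyond the scatter), a far larger weakening than a number 19.5 percentage points higher from compound 1 to compound 2 (beyond the scatter). Compound 3 also crosses to the positive side of zero, at 40.5%, so at this concentration the change does more than trim the effect seen with the two earlier compounds. The swap removes the amino nitrogen, with its hydrogen-bond donor, and the chlorine together, and nothing available explains why the number moves so far.

Which of these losses carries the step remains open. A (3-(trifluoromethyl)phenyl)amino group or a 4-chloro-3-(trifluoromethyl)phenyl group on the carbonyl carbon would help to separate them.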